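Methoxy to Trifluoromethyl: Does the Large Drop Repeat?

The compounds below may be only part of what the source reports. "The series", "measured", "known", "first", "only" and "open" are said of these compounds alone.

Three compounds have been measured in an assay on isolated protein for inhibition of protein kinase C zeta type (Homo sapiens), with stated times of 1 h and 2.5 min, tested at 30 uM; on this read-out lower numbers stand for less inhibition and higher numbers for more inhibition at the one concentration tested (going by the name of the read-out):

Compound 1, `CCOC(=O)c1c(-c2cccc(OC)c2)csc1N`, gives 82%.
Compound 2, `CCOC(=O)c1c(-c2cccc(C(F)(F)F)c2)csc1N`, gives 30%.
Compound 3, `COc1ccc(-c2csc(N)c2C(=O)OCc2ccccc2)cc1`, gives 86%.

Compound 1 and compound 2 differ in one place only: trifluoromethyl in place of methoxy on an aromatic carbon. That single change produced a number 52 percentage points lower from compound 1 to compound 2 (beyond the scatter), a step far outside the usual scatter of repeated measurements. Compound 3 shares the core with compound 1 but differs from it in more than one place, so the difference between the two cores is not broken down here. The numbers for compound 1 and compound 3 lie within the scatter of each other, and nothing can be read into their order.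

Compound 4, `Nc1scc(-c2ccc(C(F)(F)F)cc2)c1C(=O)OCc1ccccc1`, has not yet been measured. It stands to compound 3 as compound 2 stands to compound 1: trifluoromethyl in place of methoxy on an aromatic carbon. The place is not identical, though. In compound 1 to compound 2 the change sits meta to a large group, whereas in compound 3 to compound 4 it sits para to a large group, so this is the same kind of change rather than the same change.

Among the compounds with values here, with only one earlier example of this change, the expectation rests on compound 1 and compound 2, where a number 52 percentage points lower from compound 1 to compound 2 (beyond the scatter) was seen. A step of similar size, a number 51 percentage points lower from compound 3 to compound 4 (beyond the scatter), is expected for compound 4 in this assay, with wide uncertainty because the place differs. Compound 4 is estimated at 35%, most likely between 10% and 65%.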

Compound 4, a percentage reported as inhibition, at one concentration (the size of the read-out at that concentration, not a potency): 21%
Compound 4: middle estimate off by 14 percentage points, on the high side, within the range that was stated.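

In this assay, putting trifluoromethyl in place of methoxy, para to a large group, gives a number 65 percentage points lower from compound 3 to compound 4 (beyond the scatter), a second large step in the same direction as the first. Set side by side, the two steps show that this change carried over from one core to the other, and that its size held up as far as this assay can tell: the same change on two cores in this assay, a number 52 percentage points lower (beyond the scatter) from compound 1 to compound 2 and a number 65 percentage points lower (beyond the scatter) from compound 3 to compound 4, 13 percentage points apart, within the scatter of two such steps. Within the data shown here, this is still only two pairs of compounds, which differ from each other both in the core and in where the group sits on the ring, and they show neither which of those differences matters, nor why the change lowers the number, nor that it would hold on any further core.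

The compounds shown leave open how other groups in the same place would compare with methoxy and trifluoromethyl, for example a single fluorine, a hydroxyl, an amine or a carboxylic acid. They also leave open what happens when methoxy and trifluoromethyl are compared at both places on one and the same core, a comparison that would separate the influence of the place from that of the core.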